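Nitrophenyl position on two ester-bearing cores

The source may hold more compounds than are shown below. What is called first, only, known or untested is meant among the compounds shown, and "the series" means these compounds.

Values in a functional assay on HEK293 cells for antagonist activity at Voltage-dependent L-type calcium channel subunit alpha-1C (Oryctolagus cuniculus), read by FLIPR; a lower number here means a stronger inhibitor, a higher number a weaker inhibitor:
compound 1 `CCOC(=O)C1=C(C)NC(COC)=C(C(=O)OC)C1c1ccccc1[N+](=O)[O-]`: 1760 nM
compound 2 `CCOC(=O)C1=C(C)NC(COC)=C(C(=O)OC)C1c1cccc([N+](=O)[O-])c1`: 14 nM
compound 3 `C=CCOC(=O)C1=C(C)NC(C)=C(C(=O)OC)C1c1ccccc1[N+](=O)[O-]`: 8 nM

Compound 2 differs from compound 1 by 3-nitrophenyl in place of 2-nitrophenyl on a saturated ring carbon, and this one change gives a 130-fold lower number from compound 1 to compound 2 (2.10 log units; beyond the scatter). Compound 3 sits on a different core; the difference between the two cores is not broken down here. The values of compound 3 and compound 2 lie within the scatter of each other, while compound 1 sits far above both.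

Compound 4 `C=CCOC(=O)C1=C(C)NC(C)=C(C(=O)OC)C1c1cccc([N+](=O)[O-])c1` is not yet measured. It differs from compound 3 by 3-nitrophenyl in place of 2-nitrophenyl on a saturated ring carbon, the same kind of change as from compound 1 to compound 2, not the same: around the place in compound 1 the neighbouring ring atom bears an ethoxycarbonyl group and the atoms two ring bonds away bear a methoxymethyl group and a methyl group, whereas in compound 3 the neighbouring ring atom bears an allyloxycarbonyl group and both atoms two ring bonds away bear a methyl group.

A smaller step is expected here, because compound 3 already gives 8 nM with 2-nitrophenyl in place, far from compound 1 at 1760 nM. The expected step from compound 3 to compound 4 in this assay is a 2.7-fold lower number from compound 3 to compound 4 (0.43 log units; beyond the scatter). Compound 4 is estimated at 3 nM, between 0.5 nM and 15 nM.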

Compound 4, half-maximal inhibitory concentration: 15 nM
Compound 4: middle estimate off by 5.0-fold (0.70 log units), on the low side; low and high end bracket the measured number.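

In this assay, 3-nitrophenyl in place of 2-nitrophenyl on the core of compound 3 gives a 1.9-fold higher number from compound 3 to compound 4 (0.27 log units; within the scatter) and so leaves the number within the usual scatter. The same change does not carry over in size between the two cores: the same change on two cores in this assay, a 130-fold lower number (2.10 log units; beyond the scatter) from compound 1 to compound 2 and a 1.9-fold higher number (0.27 log units; within the scatter) from compound 3 to compound 4, 240-fold (2.37 log units) apart, beyond the scatter of two such steps. The large step on the core of compound 1 therefore cannot be assumed on another core in this series, but the two cores differ in more than one group, ethoxycarbonyl against allyloxycarbonyl and methoxymethyl against methyl, so the data do not show which difference matters.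

Open, from the compounds shown here alone, is how the nitrophenyl swap behaves on a core pairing ethoxycarbonyl with two methyl groups, or allyloxycarbonyl with methoxymethyl, which would separate the two differences. Also open, going by these compounds, is whether an ester with an amine on a longer chain, or a trifluoromethyl group in place of the nitro group, would follow the step of either core.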